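The source may hold more compounds than are shown below. What is called first, only, known or untested is meant among the compounds shown, and "the series" means these compounds.

Compound 1 `COc1ccc(C(=O)/C=C/c2cc(-c3ccc(OC)c(OC)c3)n3nc(-c4ccccc4)cc3n2)cc1` gives 11900 nM in a functional assay on A549 cells (Homo sapiens) for antiproliferative activity, read by MTT assay, with a stated time of 24 h; on this read-out higher numbers stand for weaker inhibition and lower numbers for stronger inhibition.
Compound 2 `COc1ccc(-c2cc(/C=C/C(=O)c3ccccc3)nc3cc(-c4ccccc4)nn23)cc1OC` gives 10700 nM in this assay.
Compound 3 `COc1ccc(-c2cc(C(=O)/C=C/c3ccc(Cl)cc3)nc3cc(-c4ccccc4)nn23)cc1OC` gives 22000 nM in this assay.

Compound 1 stands second highest of the three numbers: a 1.1-fold lower number from compound 1 to compound 2 (0.05 log units; within the scatter), and a 1.8-fold higher number from compound 1 to compound 3 (0.27 log units; within the scatter). Compound 4 `COc1ccc(C(=O)/C=C/c2cc(-c3cc(OC)c(OC)c(OC)c3)n3nc(-c4ccccc4)cc3n2)cc1` is made from compound 1 by one change: methoxy in place of hydrogen on an aromatic carbon. Among the compounds with values here, only one measured step touches a methoxy group at all, a 1.1-fold lower number from compound 1 to compound 2 (0.05 log units; within the scatter), and it removed a methoxy elsewhere in the molecule without moving the number beyond the scatter. Within the data shown here, no measured step adds a methoxy to this ring, so the change is untested here. The expectation is therefore a step of no clear direction, a 1.3-fold lower number from compound 1 to compound 4 (0.12 log units; within the scatter). Compound 4 is estimated at 9000 nM, with a range from 3000 nM to 27000 nM.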

Compound 4, half-maximal inhibitory concentration: 14600 nM
For compound 4 the middle estimate is 1.6-fold (0.21 log units) below the measured one; the measured number falls inside the stated range.
By their numbers in this assay, from the lowest: compounds 2, 1, 4 and 3 (each within the scatter of the next, the first and the last beyond it).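

Going from 3,4-dimethoxyphenyl to 3,4,5-trimethoxyphenyl gives a 1.2-fold higher number from compound 1 to compound 4 (0.09 log units; within the scatter), so this ring carries one more methoxy with no change that can be told from the scatter in this assay. Within the data shown here, this is the first measured step on this ring, since the earlier steps changed the side chain. No measurement shown here offers an explanation for this result. Still open, as far as these compounds go, is whether an amine, a hydroxyl or a carboxylic acid on that carbon would move the number, and whether the added methoxy would do the same alongside the side chains of compound 2 and compound 3.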